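The source may hold more compounds than are shown below. What is called first, only, known or untested is meant among the compounds shown, and "the series" means these compounds.

Measured so far:
compound 1, `CCCc1nc(C)c2cnnc(O)n12`, gives 56800 nM
compound 2, `Cc1nc(C(C)(C)C)n2c(O)nncc12`, gives 31000 nM
compound 3, `C=CCn1ncc2c(C)nc(CCC)n2c1=O`, gives 40000 nM

All three numbers come from a functional assay for inhibition, with Homo sapiens as the target; a lower number here means a stronger inhibitor, a higher number a weaker inhibitor. Compound 1 and compound 2 differ in a single place: tert-butyl in place of propyl on an aromatic carbon. That change made a 1.8-fold lower number from compound 1 to compound 2 (0.26 log units; within the scatter), so the two values cannot be told apart with confidence. Compound 3 carries a different core; how its core differs from that of compound 1 is not broken down here, and its value sits close to the other two, again within the scatter.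

Compound 4, `C=CCn1ncc2c(C)nc(C(C)(C)C)n2c1=O`, has not yet been measured. It is related to compound 3 by tert-butyl in place of propyl on an aromatic carbon, the same change, at the same place, that turned compound 1 into compound 2. Among the compounds with values here, the only guide is that earlier pair. For compound 4 the expected step is a 1.8-fold lower number from compound 3 to compound 4 (0.26 log units; within the scatter), because the same change once made a 1.8-fold lower number from compound 1 to compound 2 (0.26 log units; within the scatter). Whether a different core behaves alike is not known from these few compounds, so the range is kept wide. Compound 4 is therefore estimated at 22000 nM, with a likely range from 8000 nM to 60000 nM.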

Compound 4, half-maximal inhibitory concentration: > 48000 nM
Compound 4: only a limit was reported; the forecaster's own chance of this, stated with the estimate: 5%; middle value at least 2.1-fold (0.33 log units) away from the limit.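

In this assay, compound 4 gave only a limit, > 48000 nM, and not an exact number. Tert-butyl in place of propyl on an aromatic carbon therefore gave an at least 1.2-fold higher number from compound 3 to compound 4 (0.07 log units; that floor lies within the scatter), and setting this beside the earlier pair gives the following comparison: the same change on two cores in this assay, a 1.8-fold lower number (0.26 log units; within the scatter) from compound 1 to compound 2 and an at least 1.2-fold higher number (0.07 log units; that floor lies within the scatter) from compound 3 to compound 4; the limit leaves it open whether they differ This shows that the result on the core of compound 3 does not settle whether the change carries over from the core of compound 1, and it shows neither that the two cores respond alike nor that they respond differently.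

The compounds shown leave open the exact value of compound 4, and so the true size of the step to it. They also leave open whether another group on that aromatic carbon, such as an amine, a carboxylic acid or a longer chain, would move the number beyond the scatter on either core.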